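Swapping a phenyl for a cyclopentylethyl chain on the core

This account rests on a few compounds, and the source may have more. Where it says the series, first, only, none or still open, it means among the compounds named here.

Of the compounds shown here, three sharing a fused two-ring core have been measured in a functional assay on HT-29 cells (Homo sapiens) for cytotoxicity, read by sulforhodamine B assay, with a stated time of 2 days, tested at 100 uM; a higher number here means more inhibition at the concentration tested (going by the name of the read-out), a lower number less inhibition. Compound 1 `O=C(Nn1c(-c2cccc([N+](=O)[O-])c2)nc2c(-c3cccs3)n[nH]c2c1=O)c1cccnc1` gives 3.9%. Compound 2 `O=C(Nn1c(-c2cccc([N+](=O)[O-])c2)nc2c(-c3ccco3)n[nH]c2c1=O)c1ccccc1` gives 21.2%. Compound 3 `O=C(Nn1c(-c2ccccc2)nc2c(-c3ccc(Cl)cc3)n[nH]c2c1=O)c1ccccc1` gives 92%, the highest of the three numbers; its nearest neighbour is compound 2, which lies well beyond the usual scatter below it, and compound 1 sits further still.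

Compound 4 `O=C(Nn1c(CCC2CCCC2)nc2c(-c3ccc(Cl)cc3)n[nH]c2c1=O)c1ccccc1` has not been measured. It differs from compound 3 in a single place, described by 2-cyclopentylethyl in place of phenyl on an aromatic carbon. Going by the values given here, no pair of measured compounds differing in just one place is available, so the size of this kind of step cannot be read from the data; the only anchor is that compound 3 gives 92% in this assay.

Because compound 3 reaches 92%, the expectation for compound 4 starts high, but the loss of the phenyl for a non-aromatic chain is expected to cost some inhibition, giving an estimated step of a number 24 percentage points lower from compound 3 to compound 4 (beyond the scatter). Compound 4 is therefore estimated at 68%, with a plausible range from 35% to 95%.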

Compound 4, a percentage reported as inhibition, at one concentration (the size of the read-out at that concentration, not a potency): 87.3%
Estimate against measurement, compound 4: 19.3 percentage points below; the range from low to high includes it.
By their numbers in this assay, from the lowest: compound 1; then compound 2; then compounds 4 and 3 (each within the scatter of the next).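

In this assay, going by these compounds alone, putting 2-cyclopentylethyl in place of phenyl on the aromatic carbon between two ring nitrogen atoms gives a number 4.7 percentage points lower from compound 3 to compound 4 (within the scatter), the first comparison in this set of two compounds that differ in only one place. At this position and with the rest of compound 3 unchanged, the reading therefore does not depend on a six-membered aromatic ring: a two-carbon chain ending in a five-membered non-aromatic ring gives a result that cannot be told apart from that of the phenyl compound. Nothing available explains why this swap leaves the reading within the scatter.

Going by these compounds, it remains open whether this position accepts other kinds of group as well, such as an amine, a carboxylic acid or a simple methyl group, or whether the result holds only for carbon-only groups of about this size. Both readings also come from a single concentration and are not potencies, so the two compounds could still separate at lower concentrations, where their inhibition has yet to be compared.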